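Methylsulfonyl in place of methoxy: expectation for compound 4

The compounds below may be only part of what the source reports. "The series", "measured", "known", "first", "only" and "open" are said of these compounds alone.

Among the measured compounds shown here, compound 3 `COc1ccccc1OC(C)C1=NCCN1` gives 0.5 in an assay on CHO cells with Alpha-2B adrenergic receptor (Homo sapiens) as the target (on this read-out higher numbers stand for larger maximal responses and lower numbers for smaller maximal responses), the second highest of the three numbers measured so far. Compound 1 `C=C(C)c1ccccc1OC(C)C1=NCCN1` gives 0.4, and a number 0.10 higher from compound 1 to compound 3 (within the scatter) lies within the scatter. Compound 2 `CC(=O)c1ccccc1OC(C)C1=NCCN1` gives 0.6; a number 0.10 lower from compound 2 to compound 3 (within the scatter) also lies within the scatter. Compound 4 `CC(Oc1ccccc1S(C)(=O)=O)C1=NCCN1` carries the change (methylsulfonyl in place of methoxy on an aromatic carbon). For the measured compounds named here, no measured step involves methylsulfonyl. Going by the values given here, the only step beyond the scatter, a number 0.20 higher from compound 1 to compound 2 (beyond the scatter), concerns a different pair of groups, and the methoxy compound sits between the two. Compound 4 is therefore expected to show no step beyond the scatter, the estimated step being no change at the digits printed from compound 3 to compound 4 (within the scatter). The estimate for compound 4 is 0.5, with a range from 0.3 to 0.7.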

Compound 4, intrinsic activity: the largest response reached, as a fraction of the reference agonist's: 0.45
Estimate against measurement, compound 4: 0.050 above; measured number inside the range.
By their numbers in this assay, from the lowest: compounds 1, 4, 3 and 2 (each within the scatter of the next, the first and the last beyond it).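

In this assay, methylsulfonyl on this aromatic carbon cannot be told apart from methoxy (a number 0.050 lower from compound 3 to compound 4 (within the scatter)) or from 1-methylethenyl (a number 0.050 higher from compound 1 to compound 4 (within the scatter)). Acetyl is separated from it (a number 0.15 lower from compound 2 to compound 4 (beyond the scatter)), so the group with the most heavy atoms of the changes so far does not raise the maximal response to the level of compound 2. Nothing available explains these steps.

From the compounds shown here alone, whether an amine or a carboxylic acid on this carbon would go beyond the span of these four compounds stays open. So does the effect of a longer alkoxy chain in place of methoxy.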